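Cytotoxicity of side-chain variants; compound 4 expected

A few compounds are considered here, and "the series" means these few. Any claim that something is new, unique, unknown or untested is made for them only; others in the source may bear on it.

Within the data shown here, compound 1 `CCN1CCN(C[C@H]2CN(c3ccc(-n4cc(-c5ccccn5)cn4)c(F)c3)C(=O)O2)CC1` is the one member of the series with a number in an ADME assay on L02 cells (Homo sapiens) for cytotoxicity, read by MTT assay, with a stated time of 48 h; on this read-out lower numbers stand for stronger inhibition and higher numbers for weaker inhibition: compound 1 gives 99 ug/mL. Compound 2 `COC[C@H]1CN(c2ccc(-n3cc(-c4ccccn4)cn3)c(F)c2)C(=O)O1` sits at a limit of this assay, compound 2 reading > 400 ug/mL. Compound 3 `CCNC(=O)NC[C@H]1CN(c2ccc(-n3cc(-c4ccccn4)cn3)c(F)c2)C(=O)O1` likewise sits at a limit, compound 3 reading > 400 ug/mL. The steps away from compound 1 therefore read an at least 4.0-fold higher number from compound 1 to compound 2 (0.60 log units; beyond the scatter) and an at least 4.0-fold higher number from compound 1 to compound 3 (0.60 log units; beyond the scatter); what separates them from a number is the limit of > 400 ug/mL in this assay, at which 2 of the 3 values shown sit. Between the two limits, the step is a step that the two limits leave unreadable from compound 2 to compound 3.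

Compound 4 `O=C1O[C@@H](CNC(=O)C(F)(F)F)CN1c1ccc(-n2cc(-c3ccccn3)cn2)c(F)c1` alters compound 1 at the same place: ((trifluoromethyl)carbonyl)amino in place of 4-ethylpiperazin-1-yl on a saturated chain carbon bound to a saturated ring carbon. Both measured changes at this place moved in one direction and beyond the scatter, so a comparable upward step is expected for compound 4, a 4.0-fold higher number from compound 1 to compound 4 (0.61 log units; beyond the scatter). The estimate for compound 4 is 400 ug/mL, spanning 150 ug/mL to 900 ug/mL, with a fair chance that this assay again reports only a limit.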

Compound 4, half-maximal inhibitory concentration: > 400 ug/mL
Compound 4: only a limit was reported (the forecaster's own chance of this, stated with the estimate: 60%); the middle value sits exactly at the limit.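

In this assay the change to ((trifluoromethyl)carbonyl)amino gives an at least 4.0-fold higher number from compound 1 to compound 4 (0.60 log units; beyond the scatter) and is the third replacement of 4-ethylpiperazin-1-yl at this place to move the same way, here with a group that has no ring. Compound 4 reads > 400 ug/mL and this is a limit, not a number. The steps among compound 2, compound 3 and compound 4 cannot be read, so these replacements stay unranked: the limit of > 400 ug/mL in this assay, at which 3 of the 4 values shown sit.

As far as these compounds go, whether the lower number of compound 1 follows the ring or the amine nitrogens of 4-ethylpiperazin-1-yl remains open. Morpholin-4-yl and an open-chain diethylamino group at this place would separate the two.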